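An Acid-Bearing Pyridyl Replaces the Piperidine

A few compounds are considered here, and "the series" means these few. Any claim that something is new, unique, unknown or untested is made for them only; others in the source may bear on it.

Compound 1: `CCC(C)(C)Cc1c[nH]c(CCc2ccc(-c3ccncc3)cc2)n1` — 103 nM
Compound 2: `CCC(C)(C)Cc1c[nH]c(CCc2ccc(N3CCCCC3)cc2)n1` — 133 nM

In a functional assay on HEK293 cells for agonist activity at Bombesin receptor subtype-3 (Mus musculus), read by luminescence and calcium flux, with a stated time of 10 min (a lower number here means that less compound is needed, a higher number that more compound is needed for the effect), compound 1 gives 103 nM, while compound 2 gives 133 nM. Within the data shown here, the single measured step, a 1.3-fold higher number from compound 1 to compound 2 (0.11 log units; within the scatter), shows that exchanging the pyridin-4-yl for a piperidin-1-yl changed little. Compound 2 thus holds the higher of the two numbers, with compound 1 its nearest neighbour within the scatter.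

Compound 3, `CCC(C)(C)Cc1c[nH]c(CCc2ccc(-c3cccnc3C(=O)O)cc2)n1`, differs from compound 2 in one place: 2-carboxypyridin-3-yl in place of piperidin-1-yl on an aromatic carbon. The measured step bears on this only in part: it shows that a six-membered ring attached at this aromatic carbon can be swapped for another without moving the number beyond the scatter. Among the measured compounds shown here, no measured compound carries a carboxylic acid, so that part of the change is untested. Compound 3 is expected to show a step of a 1.9-fold higher number from compound 2 to compound 3 (0.27 log units; within the scatter) toward a higher number, though this is uncertain. Compound 3 is therefore estimated at 250 nM, within 70 nM to 1200 nM.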

Compound 3, half-maximal effective concentration: 97 nM
Compound 3: the middle estimate sits 2.6-fold (0.41 log units) above what was measured; the range from low to high includes it.
By their numbers in this assay, from the lowest: compounds 3, 1 and 2 (each within the scatter of the next).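

In this assay, 2-carboxypyridin-3-yl takes the place of piperidin-1-yl with a 1.4-fold lower number from compound 2 to compound 3 (0.14 log units; within the scatter) and of pyridin-4-yl with a 1.1-fold lower number from compound 1 to compound 3 (0.03 log units; within the scatter), so all three groups on this aromatic carbon lie within the scatter of one another. Among these compounds, the earlier pair compared only two groups without a carboxylic acid; this result extends the flat picture to a group of 9 heavy atoms, against 6 for piperidin-1-yl, that adds a carboxylic acid and a hydrogen-bond donor. Nothing available explains why the number stays put.

Whether the carboxylic acid itself contributes remains open: neither a plain pyridin-3-yl nor the methyl ester of the acid appears among these compounds. Also open, from the compounds shown here alone, is whether an amine or a longer chain at this position would keep the number within the same scatter.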